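Trading a Carbamate Tail for a Short Alcohol

The compounds below may be only part of what the source reports. "The series", "measured", "known", "first", "only" and "open" are said of these compounds alone.

Of the compounds shown here, three sharing one core have been tested in an assay on HEK293 cells for displacement of a labelled ligand from NPC1-like intracellular cholesterol transporter 1 (Homo sapiens); a higher number here means a weaker inhibitor, a lower number a stronger inhibitor. Compound 1 `CC(C)(C)OC(=O)NCCNC(=O)CN1CN(c2ccccc2)C2(CCN(C(=O)c3ccc(C(C)(C)C)cc3)CC2)C1=O` gives 10900 nM, the highest of the three numbers, so it is the weakest inhibitor in this set. Compound 3 `CC(C)(C)OC(=O)NC1CCN(C(=O)CN2CN(c3ccccc3)C3(CCN(C(=O)c4ccc(C5CCCCC5)cc4)CC3)C2=O)CC1` gives 4800 nM, and compound 2 `CCC1CCCN(C(=O)CN2CN(c3ccccc3)C3(CCN(C(=O)c4ccc(C5CCCCC5)cc4)CC3)C2=O)C1` gives 2600 nM; both sit beyond the usual scatter from compound 1, compound 2 the furthest. Compounds 2 and 3 differ from compound 1 in more than one place, so no single change can be read from them.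

Compound 4 `CC(C)(C)c1ccc(C(=O)N2CCC3(CC2)C(=O)N(CC(=O)NCCCCO)CN3c2ccccc2)cc1` keeps the core of compound 1 and alters only the tail on the side chain: 2-hydroxyethyl in place of (tert-butoxycarbonyl)amino on a saturated chain carbon, two bonds along the chain from an amide-type nitrogen. The (tert-butoxycarbonyl)amino group that leaves is large and carries one hydrogen-bond donor and two acceptors; the 2-hydroxyethyl group that enters is small, with one donor and one acceptor. Nothing measured here isolates this kind of swap, so the direction of the step is uncertain. The expectation is for compound 4 a step of a 1.1-fold higher number from compound 1 to compound 4 (0.04 log units; within the scatter) from compound 1, that is, essentially no change beyond the scatter. Compound 4 is therefore estimated at 12000 nM in this assay , with a range from 4000 nM to 36000 nM.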

Compound 4, half-maximal inhibitory concentration: 19200 nM
The estimate for compound 4 lay 1.6-fold (0.20 log units) below the measured number; measured number inside the range.
By their numbers in this assay, from the lowest: compounds 2 and 3 (each within the scatter of the next); then compounds 1 and 4 (each within the scatter of the next).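

Among these compounds, this is the first pair in the set that differs in one place, so a single change can finally be read. In this assay, putting 2-hydroxyethyl in place of (tert-butoxycarbonyl)amino on a saturated chain carbon, two bonds along the chain from an amide-type nitrogen, gives a 1.8-fold higher number from compound 1 to compound 4 (0.25 log units; within the scatter), so the two compounds cannot be told apart in this assay. A group of 8 heavy atoms with no ring can thus give way to one of 3 heavy atoms here without a step beyond the scatter, although no measurement shown explains why the number holds.

On these data alone, it remains open whether an amine, a carboxylic acid or a longer chain in this place would move the number beyond the scatter from compound 1. As far as these compounds go, it is also open whether the same swap would read the same way on a compound carrying cyclohexyl where compound 1 carries tert-butyl, the feature shared by compound 2 and compound 3, which have the lowest numbers in the set.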